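A Larger Group on Compound 3

The source may report more compounds than this note shows. Statements on the series, on what has been measured and on what is new or still open speak of the compounds shown alone.

In a functional assay on MCF7 cells (Homo sapiens) for antiproliferative activity, read by MTT assay, with stated times of 24 h and 72 h (a higher number here means a weaker inhibitor, a lower number a stronger inhibitor), three compounds sharing one core have been measured. Compound 1 (`COc1ccc([C@@H]2[C@H](Oc3ccccc3)C(=O)N2c2cc(OC)c(OC)c(OC)c2)cc1`) gives 35000 nM, compound 2 (`COc1cc(N2C(=O)[C@@H](Oc3ccccc3)[C@H]2c2ccc3ccccc3c2)cc(OC)c1OC`) gives 282000 nM, and compound 3 (`COc1cc([C@@H]2[C@H](Oc3ccccc3)C(=O)N2c2cc(OC)c(OC)c(OC)c2)ccc1O`) gives 32000 nM. Compound 3 sits at the low end of these numbers, a place it shares with one neighbour: putting 4-hydroxy-3-methoxyphenyl in place of 4-methoxyphenyl gave a 1.1-fold lower number from compound 1 to compound 3 (0.04 log units; within the scatter). Putting the same group in place of naphthalen-2-yl gave an 8.8-fold lower number from compound 2 to compound 3 (0.95 log units; beyond the scatter).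

Compound 4 (`COc1ccc([C@@H]2[C@H](Oc3ccccc3)C(=O)N2c2cc(OC)c(OC)c(OC)c2)c([N+](=O)[O-])c1O`) keeps the shared core and differs at that same saturated ring carbon: a group of 12 heavy atoms (7 carbon, 1 nitrogen, 4 oxygen; one six-membered aromatic ring of carbon only) in place of a group of 9 heavy atoms (7 carbon, 2 oxygen; one six-membered aromatic ring of carbon only), on a saturated ring carbon. Two earlier changes there bear on this one. Exchanging 4-methoxyphenyl for naphthalen-2-yl gave an 8.1-fold higher number from compound 1 to compound 2 (0.91 log units; beyond the scatter), which shows that a modest step is possible at this place. The exchange between the two groups with a single six-membered aromatic ring gave no step beyond the scatter, as compound 3 at 32000 nM shows. Among the measured compounds shown here, compound 4 also has a single such ring, but no measured compound carries its group, so the direction remains open. In this assay, the expected step is therefore small, most likely none beyond the scatter: a 1.1-fold lower number from compound 3 to compound 4 (0.03 log units; within the scatter). For compound 4, the estimated value is 30000 nM, with an expected range from 10000 nM to 100000 nM.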

Compound 4, half-maximal inhibitory concentration: 89000 nM
Beside the measured number, compound 4's estimate is 3.0-fold (0.47 log units) below it; low and high end bracket the measured number.
By their numbers in this assay, from the lowest: compounds 3 and 1 (each within the scatter of the next); then compound 4; then compound 2.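

In this assay, a single-ring group at this saturated ring carbon can now shift the number beyond the scatter: the change gives a 2.8-fold higher number from compound 3 to compound 4 (0.44 log units; beyond the scatter) and also a 2.5-fold higher number from compound 1 to compound 4 (0.41 log units; beyond the scatter) even though the exchange between the two smaller single-ring groups gave only a 1.1-fold lower number from compound 1 to compound 3 (0.04 log units; within the scatter) and no step beyond the scatter. The two-ring naphthalen-2-yl group still gives the highest number of the four, with a 3.2-fold lower number from compound 2 to compound 4 (0.50 log units; beyond the scatter) as the step to the new group, so a single ring alone does not fix the number at this position, and compound 4 falls apart from both compound 3 and compound 2. Nothing shown here bears on why the new group gives these steps.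

The compounds shown leave open whether the step belongs to the entering group as a whole or to one of its parts, and whether a phenyl ring carrying an amine or a carboxylic acid at this ring carbon would stay with compound 3 or move toward compound 4. Going by these compounds, the phenoxy group is the same in all four compounds, so what another group there would do also remains open.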